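Shortening the chain toward a silyl ether: compound 4

This account rests on a few compounds, and the source may have more. Where it says the series, first, only, none or still open, it means among the compounds named here.

In a functional assay on aorta (Rattus norvegicus) (on this read-out lower numbers stand for stronger inhibition and higher numbers for weaker inhibition), the measured compounds are:
compound 1 `O=c1ccc(CCOCc2ccccc2)nn1Cc1ccccc1`, 32300 nM;
compound 2 `CC(C)(C)[Si](OCCc1ccc(=O)[nH]n1)(c1ccccc1)c1ccccc1`, 56200 nM;
compound 3 `CC(C)(C)[Si](OCCCc1ccc(=O)[nH]n1)(c1ccccc1)c1ccccc1`, 78300 nM.

Compound 3 gives the highest of these three numbers. Its nearest neighbour is compound 2, and the step of a 1.4-fold higher number from compound 2 to compound 3 (0.14 log units; within the scatter) lies within the scatter, while compound 1 sits at a lower number beyond the scatter. Compound 4 `CC(C)(C)[Si](OCc1ccc(=O)[nH]n1)(c1ccccc1)c1ccccc1` has not been measured. It differs from compound 3 by a group of 7 heavy atoms (4 carbon, 2 nitrogen, 1 oxygen; one six-membered aromatic ring with 2 hetero atoms) in place of a group of 9 heavy atoms (6 carbon, 2 nitrogen, 1 oxygen; one six-membered aromatic ring with 2 hetero atoms), on a saturated chain carbon bound to an oxygen, on a saturated chain carbon bound to an oxygen. Among the measured compounds shown here, the only measured step of this kind, a 1.4-fold higher number from compound 2 to compound 3 (0.14 log units; within the scatter), lengthened the chain and changed little; no measured pair shortens it this far. Compound 4 is therefore expected to stay within the scatter in this assay, if anything at a slightly lower number. Compound 4 is estimated at 48000 nM, with a range from 16000 nM to 140000 nM. That estimate corresponds to a 1.6-fold lower number from compound 3 to compound 4 (0.21 log units; within the scatter).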

Compound 4, half-maximal inhibitory concentration: 62600 nM
Estimate against measurement, compound 4: 1.3-fold (0.12 log units) below, within the range that was stated.
By their numbers in this assay, from the lowest: compounds 1, 2, 4 and 3 (each within the scatter of the next, the first and the last beyond it).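

In this assay the change on the saturated chain carbon bound to an oxygen gives a 1.3-fold lower number from compound 3 to compound 4 (0.10 log units; within the scatter) and a 1.1-fold higher number from compound 2 to compound 4 (0.05 log units; within the scatter) and so both steps stay within the scatter. Compound 2, compound 3 and compound 4 therefore cannot be told apart, and this now holds for the shortest chain shown as well. Nothing at hand explains why this chain length makes no measurable difference. Still open, going by these compounds, is whether a much longer chain would move the number beyond the scatter. The same question stands for an amine or a carboxylic acid in place of the silyl ether.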